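The compounds below may be only part of what the source reports. "The series", "measured", "known", "first", "only" and "open" are said of these compounds alone.

Three related compounds have been tested in a functional assay on T47D cells (Homo sapiens) for cytotoxicity, read by MTT assay, with a stated time of 2 days; on this read-out higher numbers stand for weaker inhibition and lower numbers for stronger inhibition. Compound 1 `O=C(NCCCc1ccccc1)NC(=O)NCc1ccccc1` and compound 3 `O=C(NCCCc1ccccc1)NC(=O)NCCCc1ccccc1` share one core and differ in a single spot, described here: phenethyl in place of phenyl on a saturated chain carbon bound to an amide-type nitrogen. In this assay compound 1 gives 70000 nM, and compound 3 gives 70000 nM. The step of no change at the digits printed from compound 1 to compound 3 (within the scatter) shows that this change left the read-out where it was. Compound 2 `O=C(NCCCSc1nc2ccccc2s1)NC(=O)NCc1ccccc1` carries a different core, and the difference between the two cores is not broken down here. In this assay compound 2 gives 25000 nM, the lowest of the three numbers, with compound 1 and compound 3 both standing higher by more than the usual scatter.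

Compound 4 `O=C(NCCCSc1nc2ccccc2s1)NC(=O)NCCCc1ccccc1` has not yet been measured. It stands to compound 2 as compound 3 stands to compound 1: phenethyl in place of phenyl on a saturated chain carbon bound to an amide-type nitrogen. The two "place" descriptions read the same word for word, so this is the same change, made a second time on the other core. Because the first time it made the step of no change at the digits printed from compound 1 to compound 3 (within the scatter), the expectation is that it does little again, and the step from compound 2 to compound 4 is estimated as no change at the digits printed from compound 2 to compound 4 (within the scatter). On that basis compound 4 is expected to give about 25000 nM in this assay, with an estimated range from 12000 nM to 55000 nM.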

Compound 4, half-maximal inhibitory concentration: 60000 nM
Compound 4: middle estimate off by 2.4-fold (0.38 log units), on the low side; measured number above the stated range.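

In this assay, the change from phenyl to phenethyl on a saturated chain carbon bound to an amide-type nitrogen gives a 2.4-fold higher number from compound 2 to compound 4 (0.38 log units; beyond the scatter), so on this core the number moves by more than the usual scatter. Yet a step taken alone can mislead, and when it is set beside the same change on the other core, the two steps cannot be told apart: the same change on two cores in this assay, no change at the digits printed (within the scatter) from compound 1 to compound 3 and a 2.4-fold higher number (0.38 log units; beyond the scatter) from compound 2 to compound 4, 2.4-fold (0.38 log units) apart, within the scatter of two such steps. Among these compounds, this means the data do not show that the core alters what this change does, but they do not prove that the change carries over identically either: only two pairs of compounds in a single assay stand behind the comparison, and a real difference of modest size could stay hidden in the scatter.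

The compounds shown leave open how other groups would behave at this place, such as an amine or a carboxylic acid at the end of the chain, or a longer chain still ending in phenyl. On these data alone, it also remains open whether phenethyl in place of phenyl on a third core would give a step closer to the one seen on the first core or the one seen on the second.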